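Replacing the furan-2-yl group of compound 3

This account rests on a few compounds, and the source may have more. Where it says the series, first, only, none or still open, it means among the compounds named here.

Compound 1 (`Cn1c(=O)c(=O)n(C2CCCC2)c2nc(N/N=C/c3ccc(S(C)(=O)=O)cc3)ncc21`): 84500 nM
Compound 2 (`Cn1c(=O)c(=O)n(C2CCCC2)c2nc(N/N=C/c3ccc(O)c(F)c3)ncc21`): 97800 nM
Compound 3 (`Cn1c(=O)c(=O)n(C2CCCC2)c2nc(N/N=C/c3ccco3)ncc21`): > 100000 nM

In a functional assay on A549 cells (Homo sapiens) for antiproliferative activity, read by MTT assay (on this read-out lower numbers stand for stronger inhibition and higher numbers for weaker inhibition), compound 3 has only a limit and no true number (> 100000 nM) .

The next compound, compound 4 (`Cn1c(=O)c(=O)n(C2CCCC2)c2nc(N/N=C/c3ccc(F)cc3Br)ncc21`), keeps the shared core but carries 2-bromo-4-fluorophenyl in place of furan-2-yl on a carbon with a double bond to nitrogen . The nearest evidence comes from the three measured exchanges at this same place. These are a 1.2-fold higher number from compound 1 to compound 2 (0.06 log units; within the scatter), then an at least 1.1-fold higher number from compound 1 to compound 3 (0.07 log units; that floor lies within the scatter), and finally an at least 1.0-fold higher number from compound 2 to compound 3 (0.00 log units; that floor lies within the scatter). None of these shows a change beyond the scatter, though the two steps to compound 3 give only floors. None of the three compounds carries the new group, so this evidence is indirect. No clear step in either direction is therefore expected in this assay, and compound 4 may also reach the limit. The estimated step is an at least 1.2-fold lower number from compound 3 to compound 4 (0.09 log units; that floor lies within the scatter). Compound 4 is estimated at 80000 nM with an expected range from 30000 nM to 130000 nM.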

Compound 4, half-maximal inhibitory concentration: 6590 nM
Estimate against measurement, compound 4: 12-fold (1.08 log units) above, and the stated range ends above it.
By their numbers in this assay, from the lowest: compound 4; then compounds 1 and 2 (each within the scatter of the next). At a limit, above all of these: compound 3.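

In this assay, the exchanges among the earlier groups at this position stayed within the scatter, but 2-bromo-4-fluorophenyl on the carbon with a double bond to nitrogen brings a clear change: a 15-fold lower number from compound 2 to compound 4 (1.17 log units; beyond the scatter) and a 13-fold lower number from compound 1 to compound 4 (1.11 log units; beyond the scatter). Against furan-2-yl the result is an at least 15-fold lower number from compound 3 to compound 4 (1.18 log units; beyond the scatter), so this position can strongly shift the antiproliferative read-out, which the three earlier groups gave no sign of. The value of compound 3 is a limit and not a true number, which makes that last step a floor: the limit of > 100000 nM in this assay, at which 1 of the 4 values shown sits.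

The compounds shown do not separate the contribution of the bromine from that of the fluorine in the new group. They also do not tell how a phenyl ring carrying an amine or a carboxylic acid would behave at this place.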